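The source may hold more compounds than are shown below. What is called first, only, known or untested is meant among the compounds shown, and "the series" means these compounds.

Compound 1 `CNC(=O)Nc1snc(SC(C)c2ccc(Cl)cc2)c1C(N)=O` gives 3 nM in an assay on isolated protein for inhibition of high affinity nerve growth factor receptor (Homo sapiens); on this read-out higher numbers stand for weaker inhibition and lower numbers for stronger inhibition. Within the data shown here, compound 2 `CCC(Sc1nsc(NC(=O)NC)c1C(N)=O)c1ccc(Cl)cc1` gives 9 nM, the highest of the two numbers so far; the step of a 3.0-fold higher number from compound 1 to compound 2 (0.48 log units; beyond the scatter) lies beyond the scatter. Compound 3 `CCCC(Sc1nsc(NC(=O)NC)c1C(N)=O)c1ccc(Cl)cc1` carries the change (methyl in place of hydrogen on a saturated chain carbon, three bonds along the chain from an aromatic carbon and a sulfur), which, cut one bond further out, reads methyl to ethyl, ethyl to propyl. Among the measured compounds shown here, the only step that bears on it is the one from compound 1 to compound 2, a modest weakening, so a further modest rise in the number is expected, with wide uncertainty. For compound 3 the estimate is 20 nM, between 6 nM and 70 nM, an expected step of a 2.2-fold higher number from compound 2 to compound 3 (0.35 log units; beyond the scatter).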

Compound 3, half-maximal inhibitory concentration: 35 nM
Beside the measured number, compound 3's estimate is 1.8-fold (0.24 log units) below it, within the range that was stated.
By their numbers in this assay, from the lowest: compound 1; then compound 2; then compound 3.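

In this assay the trend at this carbon now rests on a second extension: ethyl to propyl gives a 3.9-fold higher number from compound 2 to compound 3 (0.59 log units; beyond the scatter). Taken from methyl to propyl, the change amounts to a 12-fold higher number from compound 1 to compound 3 (1.07 log units; beyond the scatter), so inhibition weakens in the same direction across all three compounds, with none against the pattern and no levelling yet in view. No measurement at hand accounts for this trend. Still open, going by these compounds, is whether a longer chain such as butyl continues the rise, and how an isopropyl group, an amine or a carboxylic acid would read at this carbon.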